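The compounds below may be only part of what the source reports. "The series", "measured", "known", "first", "only" and "open" are said of these compounds alone.

Compound 1 `CC(C)(C)CC[C@H](c1ccc(C(=O)NCc2nn[nH]n2)cc1)N1C(=O)C(c2cncc(Cl)c2)=N[C@]12CC[C@@H](C(C)(C)C)CC2`: 84 nM
Compound 2 `CC1(CC[C@H](c2ccc(C(=O)NCc3nn[nH]n3)cc2)N2C(=O)C(c3cc(Cl)cc(Cl)c3)=N[C@]23CC[C@@H](C(C)(C)C)CC3)CC1`: 110 nM
Compound 3 `CC(C)(C)[C@H]1CC[C@]2(CC1)N=C(c1ccc(Cl)cc1)C(=O)N2Cc1ccc(C(=O)NCCC(=O)O)cc1` gives only a limit of the assay: > 10000 nM

All three numbers come from an assay on membranes from liver for displacement of a labelled ligand from Glucagon receptor (Mus musculus), read by scintillation counting, with a stated time of 60 min; a higher number here means a weaker inhibitor, a lower number a stronger inhibitor. Of the two compounds that returned an actual number, compound 1 has the lower one, but the gap to compound 2 lies within the scatter of repeated measurements, so the two cannot be told apart on these data. Compound 3 returned no number at all, only the limit at which one of the three values sits (the limit of > 10000 nM in this assay, at which 1 of the 3 values shown sits); it differs from compound 1 in more than one place, so it says nothing about any single change.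

Compound 4 `CC(C)(C)CC[C@H](c1ccc(C(=O)NCc2nn[nH]n2)cc1)N1C(=O)C(c2cccc(C(F)(F)F)c2)=N[C@]12CC[C@@H](C(C)(C)C)CC2` has not yet been measured in this assay. It differs from compound 1 in one place only: 3-(trifluoromethyl)phenyl in place of 5-chloropyridin-3-yl on a carbon with a double bond to nitrogen. Within the data shown here, no measured pair in this set isolates such an exchange, so the size of the step is open. The expectation is a step no larger than the usual scatter, leaning if anything toward a slightly weaker inhibitor, so the step of a 1.8-fold higher number from compound 1 to compound 4 (0.25 log units; within the scatter) is expected to be small. Compound 4 is therefore estimated at 150 nM, with a likely range from 50 nM to 500 nM.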

Compound 4, half-maximal inhibitory concentration: 140 nM
Compound 4: middle estimate off by 1.1-fold (0.03 log units), on the high side, and the stated range covers the measured number.
By their numbers in this assay, from the lowest: compounds 1, 2 and 4 (each within the scatter of the next). At a limit, above all of these: compound 3.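

The exchange of 5-chloropyridin-3-yl for 3-(trifluoromethyl)phenyl in this assay gives a 1.7-fold higher number from compound 1 to compound 4 (0.22 log units; within the scatter), so compound 1 and compound 4 cannot be told apart on this measurement. Among these compounds, this is the first direct view of this position, on a carbon with a double bond to nitrogen: in this pair, a ring of carbon only, with no hydrogen-bond acceptor and 10 heavy atoms rather than 7, takes the place of the chlorine-bearing pyridine ring without a step beyond the scatter. The data shown offer no measurement that could explain this result.

The exchange also alters two things at once, the ring nitrogen and the chlorine giving way to carbon and trifluoromethyl, so the contribution of each remains unresolved, and any effects of opposite direction could be hidden within the small step. From the compounds shown here alone, it also remains open whether this tolerance extends to a plain phenyl ring, or to a ring carrying an amine or a carboxylic acid, at the same place.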